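A nitro group in place of bromine on the aryl ring

A few compounds are considered here, and "the series" means these few. Any claim that something is new, unique, unknown or untested is made for them only; others in the source may bear on it.

Three compounds built on one shared core, each carrying an aryl group on a saturated ring carbon, have been tested in a functional assay on HeLa cells (Homo sapiens) for cytotoxicity, read by MTT assay; on this read-out higher numbers stand for weaker inhibition and lower numbers for stronger inhibition. In this assay compound 1 `CCOC(=O)C12C(=O)OCC=C1COC2c1ccccc1F` gives 22100 nM. Compound 3 `CCOC(=O)C12C(=O)OCC=C1COC2c1ccc(Br)cc1` gives 48700 nM, the higher of the two numbers, with a 2.2-fold higher number from compound 1 to compound 3 (0.34 log units; beyond the scatter). Compound 2 `CCOC(=O)C12C(=O)OCC=C1COC2c1cccc(Cl)c1` reaches only the limit of this assay, > 1000000 nM (the limit of > 1000000 nM in this assay, at which 1 of the 3 values shown sits). From that limit, an at least 20-fold lower number from compound 2 to compound 3 (1.31 log units; beyond the scatter), and an at least 45-fold higher number from compound 1 to compound 2 (1.65 log units; beyond the scatter).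

Compound 4 `CCOC(=O)C12C(=O)OCC=C1COC2c1ccc([N+](=O)[O-])cc1` differs from compound 3 by nitro in place of bromo on an aromatic carbon, para to a large group. For the measured compounds named here, none of the measured steps replaces a group at that same place; each exchanges one halophenyl for another, with sizes from modest to large. The measured steps therefore give little direct guidance, and only a modest step is expected in this assay, a 1.1-fold lower number from compound 3 to compound 4 (0.03 log units; within the scatter). Compound 4 is estimated at 45000 nM, with a range from 10000 nM to 250000 nM.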

Compound 4, half-maximal inhibitory concentration: 53400 nM
Compound 4: the middle estimate sits 1.2-fold (0.07 log units) below what was measured, within the range that was stated.
By their numbers in this assay, from the lowest: compound 1; then compounds 3 and 4 (each within the scatter of the next). At a limit, above all of these: compound 2.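

In this assay bromo and nitro, on an aromatic carbon para to a large group, cannot be told apart: a 1.1-fold higher number from compound 3 to compound 4 (0.04 log units; within the scatter). The earlier steps each exchanged one halophenyl for another, so this is the first step shown that keeps the place fixed and brings in a group that is not a halogen. Bromo, with 1 heavy atom, and nitro, with 3 heavy atoms and 2 hydrogen-bond acceptors, give values within the scatter of each other, and nothing in the data shown bears on why they read alike.

Going by these compounds, it remains open whether a group of another kind at this place, such as an amine or a carboxylic acid, would read like bromo and nitro. Also open, on these data alone, is how nitro would read elsewhere on the aryl ring.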